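The source may hold more compounds than are shown below. What is called first, only, known or untested is meant among the compounds shown, and "the series" means these compounds.

In a functional assay on MCF7 cells (Homo sapiens) for inhibition, read by sulforhodamine B assay, with a stated time of 48 h, tested at 50 uM (on this read-out lower numbers stand for less inhibition of growth and higher numbers for more inhibition of growth at the one concentration tested), compound 2 (`CCOc1ccc([C@@H]2CC(=O)c3cc(CC=C(C)C)c(OC)cc3O2)cc1`) gives 57% and compound 1 (`CCCOc1ccc([C@@H]2CC(=O)c3cc(CC=C(C)C)c(OC)cc3O2)cc1`) gives 60%, so the two cannot be told apart. Within the data shown here, the only measured step, a number 3 percentage points lower from compound 1 to compound 2 (within the scatter), lies within the scatter. Compound 3 (`COc1cc2c(cc1CC=C(C)C)C(=O)C[C@@H](c1ccc(Oc3ccc(Br)cc3)cc1)O2`) has not yet been measured and carries a much larger change: 4-bromophenyl in place of ethyl on an oxygen on an aromatic ring. In short, this is 4-bromophenyl in place of ethyl on an oxygen on an aromatic ring. Among the measured compounds shown here, the measured step bears on this only loosely: it concerns a single methyl on the chain, whereas here the ethyl gives way to a ring, and no measured compound has a ring at this place. The data therefore set no firm direction. The expected step is a number 3 percentage points higher from compound 2 to compound 3 (within the scatter), not clearly beyond the scatter. Compound 3 is estimated at 60% in this assay, with an expected range from 42% to 78%.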

Compound 3, percent growth inhibition at one concentration: 68%
Compound 3: the middle estimate sits 8 percentage points below what was measured; measured number inside the range.
By their numbers in this assay, from the lowest: compounds 2, 1 and 3 (each within the scatter of the next, the first and the last beyond it).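

In this assay, among these compounds, the oxygen on the aromatic ring accepts a ring as well as a short chain: 4-bromophenyl in place of ethyl gives a number 11 percentage points higher from compound 2 to compound 3 (beyond the scatter), the first step to lie beyond the scatter, though a modest one. Against propyl the same kind of change gives a number 8 percentage points higher from compound 1 to compound 3 (within the scatter), so the separation holds against ethyl only and not against the longer chain. Nothing measured here accounts for the step.

On these data alone, whether the ring itself or its bromine matters stays open, and a plain phenyl or a 4-chlorophenyl on this oxygen would separate the two. Also open, as far as these compounds go, is how a benzyl group, or a phenyl ring carrying an amine or a carboxylic acid, would read at this place.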